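Methylsulfanyl in place of the selenium group on two cores

This account rests on a few compounds, and the source may have more. Where it says the series, first, only, none or still open, it means among the compounds named here.

Compound 1 `O=C(/N=C(/NC(=O)c1cc(-c2ccccc2)nc2ccccc12)[Se]Cc1ccccc1)c1cc(-c2ccccc2)nc2ccccc12` gives 9060 nM in a functional assay on K562 cells (Homo sapiens) for cytotoxicity, read by MTT assay, with a stated time of 72 h (on this read-out lower numbers stand for stronger inhibition of growth and higher numbers for weaker inhibition of growth), the lowest of the three measured numbers. Compound 2 `O=C(/N=C(/NC(=O)c1cccs1)[Se]Cc1ccccc1)c1cccs1` gives 29500 nM in this assay, and compound 3 `CS/C(=N\C(=O)c1cccs1)NC(=O)c1cccs1` gives 72600 nM. The difference between the cores of compound 1 and compound 2 is not broken down here. Compound 2 and compound 3 differ by a group of 2 heavy atoms (1 carbon, 1 sulfur; no ring) in place of a group of 8 heavy atoms (7 carbon, 1 selenium; one six-membered aromatic ring of carbon only), on a carbon with a double bond to nitrogen, and this gave a 2.5-fold higher number from compound 2 to compound 3 (0.39 log units; beyond the scatter). Compound 4 `CS/C(=N\C(=O)c1cc(-c2ccccc2)nc2ccccc12)NC(=O)c1cc(-c2ccccc2)nc2ccccc12` carries the same change on the core of compound 1, (a group of 2 heavy atoms (1 carbon, 1 sulfur; no ring) in place of a group of 8 heavy atoms (7 carbon, 1 selenium; one six-membered aromatic ring of carbon only), on a carbon with a double bond to nitrogen); the surroundings of the place match word for word, so it is the same change. The step from compound 1 to compound 4 is expected to be a 2.4-fold higher number from compound 1 to compound 4 (0.39 log units; beyond the scatter), beside the earlier one, because the single measured occurrence of this change a 2.5-fold higher number from compound 2 to compound 3 (0.39 log units; beyond the scatter) was modest and beyond the scatter; with one precedent the range stays wide. Compound 4 is therefore estimated at 22000 nM, between 9000 nM and 60000 nM.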

Compound 4, concentration for 50% growth inhibition: 34400 nM
Compound 4: middle estimate off by 1.6-fold (0.19 log units), on the low side; the range from low to high includes it.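

In this assay, methylsulfanyl in place of the selenium group gives a 3.8-fold higher number from compound 1 to compound 4 (0.58 log units; beyond the scatter), and the step agrees with the one on the other core: the same change on two cores in this assay, a 2.5-fold higher number (0.39 log units; beyond the scatter) from compound 2 to compound 3 and a 3.8-fold higher number (0.58 log units; beyond the scatter) from compound 1 to compound 4, 1.5-fold (0.19 log units) apart, within the scatter of two such steps

On these two cores, the change carries over in direction and in size. This does not show that it would carry over to a third core, and it does not tell whether the selenium or the aromatic ring of the leaving group accounts for the step.

The compounds shown leave these two parts unseparated; a benzylsulfanyl group or a methylselanyl group on either core would address that. Also open, going by these compounds, is how an amine or a longer alkylsulfanyl chain would behave on the same carbon.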